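This account rests on a few compounds, and the source may have more. Where it says the series, first, only, none or still open, it means among the compounds named here.

Measured compounds in this series:

compound 1, `COc1cc(/C=C/c2ccc(S(N)(=O)=O)cc2)cc(OC)c1`, 18600 nM
compound 2, `COc1cccc(/C=C/c2ccc(S(N)(=O)=O)cc2)c1`, 26800 nM
compound 3, `NS(=O)(=O)c1ccc(/C=C/c2ccc(F)cc2)cc1`, 12900 nM

All three values come from a functional assay on MOLT-4 cells (Homo sapiens) for inhibition; on this read-out higher numbers stand for weaker inhibition of growth and lower numbers for stronger inhibition of growth. For the measured compounds named here, compound 2 has the highest number of the three; the one single-point step among the measured compounds is a 1.4-fold higher number from compound 1 to compound 2 (0.16 log units; within the scatter), and compound 3 sits a little further off, with a difference to compound 2 that lies beyond the scatter.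

Compound 4, `NS(=O)(=O)c1ccc(/C=C/c2cccc(O)c2)cc1`, is not yet measured. It differs from compound 2 by hydrogen in place of methyl on an oxygen on an aromatic ring. Going by the values given here, no measured step in the set changes a methyl on an oxygen on an aromatic ring, so nothing bears directly on this change. Among the compounds with values here, the only single-point step known, from compound 1 to compound 2, removes a whole methoxy group and stays within the scatter; the set as a whole spans a narrow range. The step from compound 2 to compound 4 is therefore expected to be small in this assay, with no clear direction, and is estimated as a 1.2-fold lower number from compound 2 to compound 4 (0.09 log units; within the scatter). Compound 4 is expected to give about 22000 nM in this assay, within a range of 9000 nM to 55000 nM.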

Compound 4, concentration for 50% growth inhibition: 20000 nM
Compound 4: the middle estimate sits 1.1-fold (0.04 log units) above what was measured; the measured number falls inside the stated range.
By their numbers in this assay, from the lowest: compounds 3, 1, 4 and 2 (each within the scatter of the next, the first and the last beyond it).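

In this assay the first change made on the oxygen itself, methoxy to hydroxy, gives a 1.3-fold lower number from compound 2 to compound 4 (0.13 log units; within the scatter); the methyl can thus be lost here without a step beyond the scatter. Earlier, only the loss of a whole methoxy group had been seen, as a 1.4-fold higher number from compound 1 to compound 2 (0.16 log units; within the scatter), so both single-point steps now shown stay within the scatter. No available evidence explains this result.

The compounds shown leave open whether a longer chain on the same oxygen, such as ethyl in place of methyl, would give a step beyond the scatter. As far as these compounds go, whether an amine or a carboxylic acid in place of the hydroxy would do so also remains open.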